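Adding a Hydroxyl to Compound 1

The source may hold more compounds than are shown below. What is called first, only, known or untested is meant among the compounds shown, and "the series" means these compounds.

The measured compounds:
compound 1, `COc1ccc(C(=O)/C=C/c2ccc(Br)cc2)c2c1C=CC(C)(C)O2`, gives > 10000 nM
compound 2, `COc1ccc(C(=O)/C=C/c2ccc(-n3ccnc3)cc2)c2c1C=CC(C)(C)O2`, gives > 10000 nM
compound 3, `COc1ccc(C(=O)/C=C/c2ccc3ccccc3n2)c2c1C=CC(C)(C)O2`, gives 4530 nM

In a functional assay on HCT-116 cells (Homo sapiens) for antiproliferative activity, read by MTT assay, with a stated time of 24 h (a lower number here means a stronger inhibitor, a higher number a weaker inhibitor), compound 1 reaches only the limit of the assay, > 10000 nM, so no number is known for it. Compound 2 likewise sits at a limit, > 10000 nM. Compound 3 gives 4530 nM. Compound 1 thus stands at the limit of > 10000 nM in this assay, at which 2 of the 3 values shown sit, and nothing places it more closely. Going by the values given here, the one step recorded from compound 1, a step that the two limits leave unreadable from compound 1 to compound 2, has no readable size; both of its ends are limits.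

Compound 4, `COc1ccc(C(=O)/C=C/c2ccc(O)c(Br)c2)c2c1C=CC(C)(C)O2`, differs from compound 1 by 3-bromo-4-hydroxyphenyl in place of 4-bromophenyl on a double-bonded chain carbon bound to a double-bonded chain carbon. Among the compounds with values here, no measured step bears on a hydroxyl entering on this ring, so no size of step in this assay can be read from the data; the expectation rests only on compound 1 standing at a limit. Compound 4 is therefore estimated at 9000 nM, within 2500 nM to 30000 nM, and most likely reported again as a limit. The step this estimate means, an at least 1.1-fold lower number from compound 1 to compound 4 (0.04 log units; that floor lies within the scatter), is expected to stay within the scatter.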

Compound 4, half-maximal inhibitory concentration: > 10000 nM
Compound 4 gave a limit, no number; the forecaster's own chance of this, stated with the estimate: 60%; middle value at least 1.1-fold (0.04 log units) from the limit.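

In this assay compound 4 gives > 10000 nM, a limit and not a number, and compound 1 is also held at a limit, so no step can be read between compound 1 and compound 4: the limit of > 10000 nM in this assay, at which 3 of the 4 values shown sit. The compounds shown leave open whether 3-bromo-4-hydroxyphenyl in place of 4-bromophenyl changes the activity at all.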